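Tosylation of a Phenol on Two Related Cores

A few compounds are considered here, and "the series" means these few. Any claim that something is new, unique, unknown or untested is made for them only; others in the source may bear on it.

Of the compounds shown here, three have been tested in a functional assay on MCF7 cells (Homo sapiens) for cytotoxicity, read by MTT assay, with a stated time of 4 days (on this read-out lower numbers stand for stronger inhibition and higher numbers for weaker inhibition), and a fourth awaits its result. Compound 1 `Cc1ccc(-c2cn(C[C@H]3c4c(ccc(O)c4C)[C@@H]4CC[C@@]5(C)C[C@]43CC5=O)nn2)cc1` carries a free hydroxy group on its aromatic ring and a ketone in its polycyclic core. In this assay compound 1 gives a value that is a limit, > 20000 nM. Compound 3 `Cc1ccc(-c2cn(C[C@H]3c4c(ccc(OS(=O)(=O)c5ccc(C)cc5)c4C)[C@@H]4CC[C@@]5(C)C[C@]43CC5=O)nn2)cc1` differs from compound 1 only by (4-methylphenyl)sulfonyl in place of hydrogen on an oxygen on an aromatic ring. In this assay compound 3 also gives a limit, > 20000 nM. The step that the two limits leave unreadable from compound 1 to compound 3 therefore cannot be read, since both values sit at the limit of > 20000 nM in this assay, at which 2 of the 3 values shown sit.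

Compound 2 `C=C1C(=O)[C@]23C[C@@]1(O)CC[C@H]2c1ccc(O)c(C)c1[C@@H]3Cn1cc(-c2ccc(OC)cc2)nn1` has a different core, with an exocyclic methylene next to its ketone, a tertiary hydroxy group and a methoxy group on its triazole-linked aryl ring; how its core differs from that of compound 1 is not broken down here. In this assay compound 2 gives 1710 nM, the only numerical result among the three.

Compound 4 `C=C1C(=O)[C@]23C[C@@]1(O)CC[C@H]2c1ccc(OS(=O)(=O)c2ccc(C)cc2)c(C)c1[C@@H]3Cn1cc(-c2ccc(OC)cc2)nn1` differs from compound 2 by (4-methylphenyl)sulfonyl in place of hydrogen on an oxygen on an aromatic ring, the same change as that from compound 1 to compound 3, made at the same kind of place. Going by these compounds, because the measured version of this change rests only on two limits (the limit of > 20000 nM in this assay, at which 2 of the 3 values shown sit), its size is unknown, and the expected step of a 2.0-fold higher number from compound 2 to compound 4 (0.31 log units; beyond the scatter) carries wide uncertainty. Compound 4 is expected to give about 3500 nM in this assay, within a range of 800 nM to 20000 nM.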

Compound 4, half-maximal inhibitory concentration: 310 nM
Compound 4: middle estimate off by 11-fold (1.05 log units), on the high side, outside the stated range (below it).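

On the core of compound 2, (4-methylphenyl)sulfonyl in place of hydrogen on an oxygen on an aromatic ring gives a 5.5-fold lower number from compound 2 to compound 4 (0.74 log units; beyond the scatter) in this assay, so on this core the change goes with stronger inhibition, not the weaker result that was expected. The same change on the core of compound 1 cannot be read, and so the two cores cannot be compared, because both results there are limits and not numbers: the limit of > 20000 nM in this assay, at which 2 of the 4 values shown sit. This shows that the change can lower the number on one core, but with a single readable pair it does not show that the step carries over to another core, nor how large it would be there.

The compounds shown leave open whether the step in this assay depends on the whole (4-methylphenyl)sulfonyl group or would also appear with a smaller group on the same oxygen, such as methanesulfonyl or acetyl. They also leave open whether an amine-bearing sulfonyl group, such as dimethylsulfamoyl, would give a step of similar size, and whether any such group could bring the core of compound 1 to a readable number.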